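The source may report more compounds than this note shows. Statements on the series, on what has been measured and on what is new or still open speak of the compounds shown alone.

The shared core of compound 1 `Fc1ccc(-c2cn3ccnc3c(-c3ccc4ncn(C5CCCCC5)c4c3)n2)cc1` and compound 2 `c1cn2cc(-c3ccsc3)nc(-c3ccc4ncn(C5CCCCC5)c4c3)c2n1` carries an aryl group on an aromatic carbon of the fused ring system. Among the compounds with values here, in a functional assay on UACC-62 cells (Homo sapiens) for inhibition, read by sulforhodamine B assay, with a stated time of 48 h, tested at 10 uM (a lower number here means less inhibition, a higher number more inhibition at the concentration tested (going by the name of the read-out)), compound 1 gives 31%, while compound 2 gives 18.4%, the lowest of the two numbers measured; the one step measured, a number 12.6 percentage points lower from compound 1 to compound 2 (beyond the scatter), is a modest fall beyond the scatter. Compound 3 `CC(=O)c1ccc(-c2cn3ccnc3c(-c3ccc4ncn(C5CCCCC5)c4c3)n2)cc1` has not yet been measured in this assay. It differs from compound 2 in one place: 4-acetylphenyl in place of thiophen-3-yl on an aromatic carbon. Within the data shown here, the only step that bears on this change is a number 12.6 percentage points lower from compound 1 to compound 2 (beyond the scatter), in which a six-membered carbon ring gave the higher number, and the 4-acetylphenyl group of compound 3 restores a six-membered carbon ring. Compound 3 is therefore expected to move upward, by about a number 9.6 percentage points higher from compound 2 to compound 3 (within the scatter), because compound 1 with its 4-fluorophenyl group reached 31%. Compound 3 is estimated at 28%, in a range from 10% to 48%.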

Compound 3, a percentage reported as inhibition, at one concentration (the size of the read-out at that concentration, not a potency): 18.5%
The estimate for compound 3 lay 9.5 percentage points above the measured number; the range from low to high includes it.
By their numbers in this assay, from the lowest: compounds 2 and 3 (each within the scatter of the next); then compound 1.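

In this assay, the change at this position gives a number 0.1 percentage points higher from compound 2 to compound 3 (within the scatter) and so shows that 4-acetylphenyl and thiophen-3-yl cannot be told apart here. A six-membered carbon ring in this place is therefore not enough on its own to give the higher number seen with 4-fluorophenyl. With the ring kept, acetyl in place of fluoro gives a number 12.5 percentage points lower from compound 1 to compound 3 (beyond the scatter), which shows that the group carried on the ring makes a difference, though nothing measured here explains it.

From the compounds shown here alone, whether an amine or a carboxylic acid on the same ring would match compound 1 at 31% or go past it remains open. So does how a longer chain in that place would read in this assay.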